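From 3-methylphenyl to 3,5-dimethylphenyl on a shared core

The source may report more compounds than this note shows. Statements on the series, on what has been measured and on what is new or still open speak of the compounds shown alone.

Compound 1, `COc1ccc(C(=O)Nc2cccc(-c3oc4cc(-c5ccc(F)cc5)ccc4c(=O)c3O)c2)cc1`, in a functional assay on GTL 16 cells for antiproliferative activity against GTL 16 cell line (Homo sapiens), read by CCK-8 assay, with a stated time of 72 h; on this read-out lower numbers stand for stronger inhibition and higher numbers for weaker inhibition: 21100 nM
Compound 2, `COc1cccc(C(=O)Nc2cccc(-c3oc4cc(-c5ccc(F)cc5)ccc4c(=O)c3O)c2)c1`, in this assay: 12500 nM
Compound 3, `Cc1cccc(C(=O)Nc2cccc(-c3oc4cc(-c5ccc(F)cc5)ccc4c(=O)c3O)c2)c1`, in this assay: 10900 nM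

Compound 3 carries the lowest of the three numbers, but neither a 1.1-fold lower number from compound 2 to compound 3 (0.06 log units; within the scatter) nor a 1.9-fold lower number from compound 1 to compound 3 (0.29 log units; within the scatter) reaches beyond the scatter, so the three compounds cannot be told apart on these data. The step of a 1.7-fold lower number from compound 1 to compound 2 (0.23 log units; within the scatter) is likewise within the scatter.

Compound 4, `Cc1cc(C)cc(C(=O)Nc2cccc(-c3oc4cc(-c5ccc(F)cc5)ccc4c(=O)c3O)c2)c1`, differs from compound 3 by methyl in place of hydrogen on an aromatic carbon. Going by the values given here, no measured pair adds a second methyl to this ring; the closest information is the exchange of methyl for methoxy (a 1.1-fold lower number from compound 2 to compound 3 (0.06 log units; within the scatter)) and the move of a single substituent around the ring (a 1.7-fold lower number from compound 1 to compound 2 (0.23 log units; within the scatter)), both small. On that basis the second methyl is expected to leave the number about where compound 3 stands, with no step beyond the scatter in either direction, and the expected step of a 1.2-fold lower number from compound 3 to compound 4 (0.08 log units; within the scatter) reflects only a slight lean toward the lower side.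

Compound 4 is therefore estimated at 9000 nM in this assay, with a range from 4000 nM to 22000 nM.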

Compound 4, half-maximal inhibitory concentration: 13500 nM
Compound 4: middle estimate off by 1.5-fold (0.18 log units), on the low side, within the range that was stated.
By their numbers in this assay, from the lowest: compounds 3, 2, 4 and 1 (each within the scatter of the next).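

Methyl in place of hydrogen on this aromatic carbon, meta to a large group and meta to a methyl group, gives a 1.2-fold higher number from compound 3 to compound 4 (0.09 log units; within the scatter) in this assay, so going from 3-methylphenyl to 3,5-dimethylphenyl brings no readable change in this assay. Going by these compounds alone, the earlier compounds carried only one substituent on this ring, and compound 4 now shows that a ring with two substituents also cannot be told apart from them, with a 1.1-fold higher number from compound 2 to compound 4 (0.03 log units; within the scatter) and a 1.6-fold lower number from compound 1 to compound 4 (0.19 log units; within the scatter), so the flat picture among compounds 1, 2 and 3 extends to a fourth compound. No measurement at hand bears on why the number responds so little to this change.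

As far as these compounds go, it remains open whether an amine, a carboxylic acid, a chlorine atom or a longer chain on this ring would carry the number beyond the scatter, since the four compounds offer only methyl and methoxy here. From the compounds shown here alone, it also remains open whether this insensitivity to the ring's substituents would hold on any other cell line or in a direct test against an isolated target.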